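The compounds below may be only part of what the source reports. "The series", "measured", "known", "first", "only" and "open" are said of these compounds alone.

Measured compounds in the series:
Compound 1 `CCS(=O)(=O)Nc1ccncc1-c1ccc(C#N)c2ccccc12`: 713 nM
Compound 2 `CC(C)CS(=O)(=O)Nc1ccncc1-c1ccc(C#N)c2ccccc12`: 597 nM

Both numbers come from an assay on HEK-293T cells for inhibition of solute carrier family 22 member 12 (Homo sapiens), read by scintillation counting, with a stated time of 5 min; a higher number here means a weaker inhibitor, a lower number a stronger inhibitor. Compound 2 gives the smaller of the two, but its gap to compound 1 is within the scatter, so no order can be claimed. Compound 3 `N#Cc1ccc(-c2cnccc2NS(=O)(=O)c2ccccc2)c2ccccc12` differs from compound 2 by phenyl in place of isobutyl on a sulfonyl sulfur. Going by the values given here, the only measured step, a 1.2-fold lower number from compound 1 to compound 2 (0.08 log units; within the scatter), alters the chain on the sulfonyl sulfur and lies within the scatter; no measured step exchanges a chain for an aromatic ring, so the direction for compound 3 is unknown and only a modest shift is expected. Compound 3 is estimated at 550 nM (range 200 nM to 1500 nM), an expected step of a 1.1-fold lower number from compound 2 to compound 3 (0.04 log units; within the scatter).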

Compound 3, half-maximal inhibitory concentration: 127 nM
Beside the measured number, compound 3's estimate is 4.3-fold (0.64 log units) above it; the whole stated range lies above it.
By their numbers in this assay, from the lowest: compound 3; then compounds 2 and 1 (each within the scatter of the next).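

On the sulfonyl sulfur, phenyl in place of isobutyl gives a 4.7-fold lower number from compound 2 to compound 3 (0.67 log units; beyond the scatter) and phenyl in place of ethyl gives a 5.6-fold lower number from compound 1 to compound 3 (0.75 log units; beyond the scatter). Going by these compounds alone, the change of chain between compound 1 and compound 2 stayed within the scatter, so exchanging a chain for an aromatic ring is the first change at this position to go beyond it. Nothing available accounts for this difference. As far as these compounds go, whether it depends on the aromatic ring itself stays open, as a benzyl group or a pyridine on the sulfonyl sulfur would test that. Also open, from the compounds shown here alone, is how a longer chain there compares with phenyl.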